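Lengthening the Chain of Compound 3

A few compounds are considered here, and "the series" means these few. Any claim that something is new, unique, unknown or untested is made for them only; others in the source may bear on it.

In a functional assay on MDA-MB-231 cells (Homo sapiens) for antiproliferative activity, read by MTT assay (a lower number here means a stronger inhibitor, a higher number a weaker inhibitor), compound 3 `CCCCC1(O)CC(=O)c2c(O)cc(O)cc2O1` gives > 87000 nM as a limit and not a number. Compound 2 `CCCC/C=C\CCCCCCCCCc1cc(=O)c2c(O)c(C)c(O)c(C)c2o1` likewise gives > 87000 nM as a limit. In this assay compound 1 `CCCC/C=C\CCCCCCCCCC1(O)CC(=O)c2c(O)cc(OCOC)cc2O1` gives 42800 nM as a true number and carries a long chain on a related core.

Compound 4 `CCCCCCCCCCCC1(O)CC(=O)c2c(O)cc(O)cc2O1` has heptyl in place of hydrogen on a saturated chain carbon, four bonds along the chain from a saturated ring carbon and otherwise matches compound 3. Going by the values given here, no measured pair isolates this change, so the only guide is compound 1 at 42800 nM in this comparison. The expected step of an at least 2.1-fold lower number from compound 3 to compound 4 (0.33 log units; beyond the scatter) is a modest one toward stronger inhibition in this assay and remains uncertain. Compound 4 is estimated at 40000 nM with an expected range from 15000 nM to 87000 nM in this assay.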

Compound 4, half-maximal inhibitory concentration: 42800 nM
Beside the measured number, compound 4's estimate is 1.1-fold (0.03 log units) below it; the measured number falls inside the stated range.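

Heptyl on this saturated chain carbon gives the shared core of compound 3 a true number rather than a limit: the change yields an at least 2.0-fold lower number from compound 3 to compound 4 (0.30 log units; that floor lies within the scatter) in this assay for this pair. How large the gain really is cannot be read, because the starting value is only a limit: the limit of > 87000 nM in this assay, at which 2 of the 4 values shown sit.

From the compounds shown here alone, whether a longer chain on this same carbon would lower the number further stays open. So does the effect of an amine or a carboxylic acid placed there.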